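An Isoxazole in Place of a Pyrazole

A few compounds are considered here, and "the series" means these few. Any claim that something is new, unique, unknown or untested is made for them only; others in the source may bear on it.

compound 1 `Cc1n[nH]cc1-c1cccc2c1CCC2c1ncc[nH]1`: 634 nM
compound 2 `COc1cccc2c1CCC2c1ncc[nH]1`: > 10000 nM, a limit of the assay
compound 3 `c1cncc(-c2cccc3c2CCC3c2ncc[nH]2)c1`: > 10000 nM, a limit of the assay

In a functional assay on CHO cells for agonist activity at Alpha-1D adrenergic receptor (Homo sapiens), read by FLIPR and calcium flux (a lower number here means that less compound is needed, a higher number that more compound is needed for the effect), compound 1 stands alone with a number; the other two values sit at the limit of > 10000 nM in this assay, at which 2 of the 3 values shown sit. Compound 4 `Cc1oncc1-c1cccc2c1CCC2c1ncc[nH]1` differs from compound 1 in one place: 5-methyl-1,2-oxazol-4-yl in place of 3-methyl-1H-pyrazol-4-yl on an aromatic carbon. Two measured steps start from the same group on compound 1. The first is an at least 15-fold higher number from compound 1 to compound 2 (1.19 log units; beyond the scatter), the second is an at least 15-fold higher number from compound 1 to compound 3 (1.19 log units; beyond the scatter); both remove the 3-methyl-1H-pyrazol-4-yl and both end at a limit, so their true size stays unreadable. The change to compound 4 removes the same group and its hydrogen-bond donor, but the entering 5-methyl-1,2-oxazol-4-yl keeps a five-membered aromatic ring with two hetero atoms and a methyl, which the two measured replacements did not. A step in the same direction, toward a higher number, is therefore expected, though the estimate allows for it to stay short of the limit: for compound 4 the expected step is a 4.7-fold higher number from compound 1 to compound 4 (0.68 log units; beyond the scatter). The estimate for compound 4 in this assay is 3000 nM, with a range from 800 nM to 12000 nM.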

Compound 4, half-maximal effective concentration: > 10000 nM
Compound 4 was reported as a limit; the forecaster's own chance of this, stated with the estimate: 35%; middle value at least 3.3-fold (0.52 log units) from the limit.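

In this assay, putting 5-methyl-1,2-oxazol-4-yl in place of 3-methyl-1H-pyrazol-4-yl gives an at least 15-fold higher number from compound 1 to compound 4 (1.19 log units; beyond the scatter), and this step ends at a limit of the assay, so its true size stays unread. Unlike methoxy and pyridin-3-yl, the entering group has the same count of heavy atoms as the group it replaces and is also a five-membered aromatic ring with 2 hetero atoms, yet these shared features do not keep a number in this assay; what changes in the counts is one ring nitrogen to oxygen, the loss of the hydrogen-bond donor and a gain in hydrogen-bond acceptors. The steps among compounds 2, 3 and 4 cannot be read, and compound 1 is the only compound left with a number: the limit of > 10000 nM in this assay, at which 3 of the 4 values shown sit.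

Which of these differences matters at this aromatic carbon remains open, as the single exchange changes them together. Also open, going by these compounds, is whether a pyrazole without its methyl, a 1,2,3-triazole or a primary amide on the same carbon would give a number in this assay.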